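A few compounds are considered here, and "the series" means these few. Any claim that something is new, unique, unknown or untested is made for them only; others in the source may bear on it.

Three compounds have so far been measured in a functional assay on DU-145 cells (Homo sapiens) for cytotoxicity, read by MTT assay, with a stated time of 2 days; on this read-out higher numbers stand for weaker inhibition and lower numbers for stronger inhibition:

Compound 1 `Fc1ccc2nc(NCCCCN3CCN(c4cccc(Cl)c4Cl)CC3)nc(NCc3ccco3)c2c1` gives 670 nM.
Compound 2 `Cc1cccc(N2CCN(CCCNc3nc(NCc4ccco4)c4cc(F)ccc4n3)CC2)c1C` gives 2660 nM.
Compound 3 `Cc1cccc(N2CCN(CCCCNc3nc(NCc4ccco4)c4cc(F)ccc4n3)CC2)c1C` gives 3320 nM.

Compound 1 stands at the lowest number of the three, which on this read-out means the strongest inhibition of cell growth. Compound 2 gives a higher number than compound 1, and compound 3 lies higher still. Among the compounds with values here, the only step between two compounds that differ in one place runs a 5.0-fold higher number from compound 1 to compound 3 (0.70 log units; beyond the scatter), and that step swaps one aromatic ring on the ring nitrogen for another.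

Compound 4 `Clc1cccc(N2CCN(CCCCNc3nc(NCc4ccco4)c4ccccc4n3)CC2)c1Cl` is not yet measured. It differs from compound 1 in a single place: hydrogen in place of fluoro on an aromatic carbon. This is a change on the shared core, far from the ring where the measured step took place, so that step gives no direct guide. Nothing among the three measured compounds shows what removing this fluoro does in this assay. Without any comparison to lean on, the expectation is a step of no size beyond the scatter, in either direction, so compound 4 is expected near the number of compound 1, with a step of a 1.2-fold higher number from compound 1 to compound 4 (0.08 log units; within the scatter). The estimate for compound 4 is therefore 800 nM, within a range from 300 nM to 2200 nM, and the measurement will show whether the loss of the fluoro matters.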

Compound 4, half-maximal inhibitory concentration: 3870 nM
Compound 4: middle estimate off by 4.8-fold (0.68 log units), on the low side; the measured number lies above the stated range.
By their numbers in this assay, from the lowest: compound 1; then compounds 2, 3 and 4 (each within the scatter of the next).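

In this assay, the fluoro on the shared core proves to matter: hydrogen in its place gives a 5.8-fold higher number from compound 1 to compound 4 (0.76 log units; beyond the scatter), a step beyond the usual scatter from the change of just one atom. The earlier compounds shown here showed such a change only for the aromatic ring on the ring nitrogen, with a 5.0-fold higher number from compound 1 to compound 3 (0.70 log units; beyond the scatter), so compound 1 now stands apart from its neighbours through two separate single changes, one on each of two distant parts of the molecule. Nothing available here tells why removing the fluoro raises the number, and no further measurement bears on the result.

The compounds shown leave open whether the number of compound 1 depends on fluoro in particular or could also be kept by another group at this position, such as chloro, methoxy or an amine. They also leave open whether removing the fluoro has a similar effect when 2,3-dimethylphenyl stands in place of 2,3-dichlorophenyl, or when the chain to the ring nitrogen is shorter or longer.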